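Swapping 2-nitrophenyl for 4-methoxyphenyl on the shared core

The source may report more compounds than this note shows. Statements on the series, on what has been measured and on what is new or still open speak of the compounds shown alone.

In a functional assay on MCF7 cells (Homo sapiens) for cytotoxicity, read by MTT assay, with a stated time of 72 h (on this read-out higher numbers stand for weaker inhibition and lower numbers for stronger inhibition), compound 1 `N#Cc1ccc(/C=C/C(=O)Nc2cc3c(Nc4ccc(F)c(Cl)c4)ncnc3cc2O[C@H]2CCOC2)cc1` gives 9830 nM, compound 2 `COc1ccc(OC)c(/C=C/C(=O)Nc2cc3c(Nc4ccc(F)c(Cl)c4)ncnc3cc2O[C@H]2CCOC2)c1` gives 36300 nM and compound 3 `O=C(/C=C/c1ccccc1[N+](=O)[O-])Nc1cc2c(Nc3ccc(F)c(Cl)c3)ncnc2cc1O[C@H]1CCOC1` gives 28400 nM. Compound 3 thus stands in the upper part of this small range, level with compound 2, as a 1.3-fold lower number from compound 2 to compound 3 (0.11 log units; within the scatter) shows, while the set also holds a 2.9-fold higher number from compound 1 to compound 3 (0.46 log units; beyond the scatter). Compound 4 `COc1ccc(/C=C/C(=O)Nc2cc3c(Nc4ccc(F)c(Cl)c4)ncnc3cc2O[C@H]2CCOC2)cc1` differs from compound 3 by one change: 4-methoxyphenyl in place of 2-nitrophenyl on a double-bonded chain carbon bound to a double-bonded chain carbon. All three measured swaps occur at this same place, and the largest of them is a 3.7-fold higher number from compound 1 to compound 2 (0.57 log units; beyond the scatter). A modest step at most is therefore expected, and more likely toward a lower number, since compound 3 already lies near the top of the range. The estimated change is a 1.6-fold lower number from compound 3 to compound 4 (0.20 log units; within the scatter). Compound 4 is estimated at 18000 nM, with an expected range of 7000 nM to 40000 nM.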

Compound 4, half-maximal inhibitory concentration: 5070 nM
Compound 4: middle estimate off by 3.6-fold (0.55 log units), on the high side; the measured number lies below the stated range.
By their numbers in this assay, from the lowest: compounds 4 and 1 (each within the scatter of the next); then compounds 3 and 2 (each within the scatter of the next).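

In this assay, going by these compounds alone, this position proves more sensitive than the earlier compounds showed, with a 5.6-fold lower number from compound 3 to compound 4 (0.75 log units; beyond the scatter) and a 7.2-fold lower number from compound 2 to compound 4 (0.85 log units; beyond the scatter) both exceeding every earlier step at this place. By contrast, a 1.9-fold lower number from compound 1 to compound 4 (0.29 log units; within the scatter) stays level, so methoxy and cyano on that aromatic carbon read alike here. The 4-methoxyphenyl and 4-cyanophenyl compounds therefore group apart from the 2-nitrophenyl and 2,5-dimethoxyphenyl compounds.

Going by these compounds, whether that split would hold for a 4-aminophenyl or 4-carboxyphenyl group on the same chain carbon remains open. Nothing available here explains the split.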